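The compounds below may be only part of what the source reports. "The series", "measured", "known", "first", "only" and "open" are said of these compounds alone.

Measured so far in a physicochemical assay for solubility, in phosphate buffer, at pH 7.4; a higher number here means a more soluble compound, a lower number a less soluble compound:

Compound 1, `COc1ccccc1C(=O)NC(=O)Nc1ccc(N2CCCCC2)c(Cl)c1`: in this assay compound 1 gives < 1 ug/mL, which is a limit of the assay and not a number.
Compound 2, `COc1ccccc1C(=O)NC(=O)Nc1ccc(-c2ccccn2)c(C(F)(F)F)c1`: in this assay compound 2 gives 19 ug/mL.
Compound 3, `COc1ccccc1C(=O)NC(=S)Nc1ccc(N2CCCCC2)c(Cl)c1`: in this assay compound 3 gives < 1 ug/mL, again a limit of the assay rather than a number.

Within the data shown here, compound 2 therefore stands alone as the one compound of the three with a numerical reading in this assay; the other two sit at the limit of < 1 ug/mL in this assay, at which 2 of the 3 values shown sit. Among the measured compounds shown here, no two of the measured compounds differ from one another in a single place, so no measured step is available to anchor the next change.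

Compound 4, `COc1ccccc1C(=O)NC(=O)Nc1ccc(-c2nccs2)c(C(F)(F)F)c1`, is the next compound to be measured in this assay. It differs from compound 2 in one place: 1,3-thiazol-2-yl in place of pyridin-2-yl on an aromatic carbon. Without any measured step of this kind in the set, the expectation rests on the change alone. The step is expected to be small, within or only just beyond the usual scatter, with a slight lean downward: the estimated step is a 1.6-fold lower number from compound 2 to compound 4 (0.20 log units; within the scatter). On that basis compound 4 is expected to give about 12 ug/mL in this assay, within a range from 4 ug/mL to 40 ug/mL.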

Compound 4, solubility: < 1 ug/mL
Compound 4: a limit, no number (the forecaster's own chance of this, stated with the estimate: 10%); at least 12-fold (1.07 log units) between middle value and limit.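

In this assay, among these compounds, 1,3-thiazol-2-yl in place of pyridin-2-yl on an aromatic carbon, ortho to a trifluoromethyl group, gives an at least 19-fold lower number from compound 2 to compound 4 (1.27 log units; beyond the scatter), the first measured step and a large one. For compound 4, the reading of < 1 ug/mL is a limit of the assay and not a number. Exchanging one aromatic ring for another at this place is thus not a neutral change in this read-out, and compound 2 remains the only compound with a numerical reading, while the others share one floor: the limit of < 1 ug/mL in this assay, at which 3 of the 4 values shown sit.

Going by these compounds, how far compound 4 lies past its limit stays open. The compounds shown give a single change at this place and no measured property that would explain the step. Also open, on these data alone, is how this assay would read with a morpholine or a carboxylic acid at this place, and whether the step would hold up with a group other than trifluoromethyl on the neighbouring carbon of the shared core.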